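One Replacement, Carried from One Core to Another

A few compounds are considered here, and "the series" means these few. Any claim that something is new, unique, unknown or untested is made for them only; others in the source may bear on it.

The measured compounds in a functional assay on HepG2 cells (Homo sapiens) for cytotoxicity, read by MTT assay, with a stated time of 72 h; a higher number here means a weaker inhibitor of growth, a lower number a stronger inhibitor of growth:
Compound 3, `CS/C(=N\C(=O)c1cc(-c2ccccc2)nc2ccccc12)NC(=O)c1cc(-c2ccccc2)nc2ccccc12`, gives 6240 nM.
Compound 2, `O=C(/N=C(/NC(=O)c1cc(-c2ccccc2)nc2ccccc12)[Se]Cc1ccccc1)c1cc(-c2ccccc2)nc2ccccc12`, gives 25800 nM.
Compound 1, `CS/C(=N\C(=O)c1ccco1)NC(=O)c1ccco1`, gives only a limit of the assay, > 100000 nM.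

Compound 3 and compound 2 share a core and differ in one place: a group of 8 heavy atoms (7 carbon, 1 selenium; one six-membered aromatic ring of carbon only) in place of a group of 2 heavy atoms (1 carbon, 1 sulfur; no ring), on a carbon with a double bond to nitrogen. This change made a 4.1-fold higher number from compound 3 to compound 2 (0.62 log units; beyond the scatter). Compound 4, `O=C(/N=C(/NC(=O)c1ccco1)[Se]Cc1ccccc1)c1ccco1`, stands to compound 1 as compound 2 stands to compound 3: a group of 8 heavy atoms (7 carbon, 1 selenium; one six-membered aromatic ring of carbon only) in place of a group of 2 heavy atoms (1 carbon, 1 sulfur; no ring), on a carbon with a double bond to nitrogen, the same change on a different core. The difference between the two cores is not broken down here. Because compound 1 already sits at the limit of > 100000 nM in this assay, at which 1 of the 3 values shown sits, compound 4 is expected to give a number no smaller, most likely a limit again. The step expected is a step that the limit leaves unreadable from compound 1 to compound 4. Compound 4 is estimated at 250000 nM, between 60000 nM and 1000000 nM.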

Compound 4, concentration for 50% growth inhibition: 7650 nM
Compound 4: the middle estimate sits 33-fold (1.51 log units) above what was measured; the measured number lies below the stated range.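

In this assay, putting the group with selenium and the six-membered aromatic ring in place of methylsulfanyl made an at least 13-fold lower number from compound 1 to compound 4 (1.11 log units; beyond the scatter). The same replacement thus went in opposite directions on the two cores, so its result in this series does not carry from one core to the other: the same change on two cores in this assay, a 4.1-fold higher number (0.62 log units; beyond the scatter) from compound 3 to compound 2 and an at least 13-fold lower number (1.11 log units; beyond the scatter) from compound 1 to compound 4, at least 54-fold (1.73 log units) apart, beyond the scatter of two such steps

Going by these compounds, compound 1 gives > 100000 nM, which is a limit of the assay and not a number, so the full size of this step stays unknown, and two cores do not show which part of the core matters.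

On these data alone, what a methylselanyl or a benzylsulfanyl group would do on either core remains open. Such groups could separate the contribution of the selenium from that of the ring.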